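This account rests on a few compounds, and the source may have more. Where it says the series, first, only, none or still open, it means among the compounds named here.

Of the compounds shown here, three sharing one core have been measured in a physicochemical assay for solubility, read by HPLC, using the shake flask method, measured as kinetic solubility, with a stated time of 2 h, at pH 7.4; a lower number here means a less soluble compound, a higher number a more soluble compound. Compound 1 `Cc1cc(NCCCc2ccccn2)n2nc(C)c(-c3ccccc3)c2n1` gives 5900 nM in this assay. Compound 2 `Cc1cc(NCc2ccccn2)n2ncc(-c3ccccc3F)c2n1` gives 5000 nM, and compound 3 `Cc1cc(NCc2ccccn2)n2nc(C)c(Nc3ccccc3)c2n1` gives 7800 nM. The number for compound 2 is the lowest of the three, but its gap to compound 1 and its gap to compound 3 both lie within the usual scatter of repeated measurements, so these three cannot be ranked on the evidence at hand.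

Compound 4 `Cc1cc(NCc2ccccn2)n2ncc(-c3cccc(N)c3)c2n1` has not yet been measured in this assay. It differs from compound 2 in one place: 3-aminophenyl in place of 2-fluorophenyl on an aromatic carbon. Within the data shown here, no pair among the measured compounds isolates a change of this kind, so there is no measured step to lean on, and the expectation rests on the structural change alone together with the value of compound 2. For compound 4 the expected step is a 2.4-fold higher number from compound 2 to compound 4 (0.38 log units; beyond the scatter), upward and modest, possibly no further than the scatter itself. Because compound 2 stands at 5000 nM, compound 4 is estimated to reach 12000 nM in this assay, with a plausible range from 5000 nM to 30000 nM.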

Compound 4, solubility: 160000 nM
Compound 4: the middle estimate sits 13-fold (1.12 log units) below what was measured; the whole stated range lies below it.
By their numbers in this assay, from the lowest: compounds 2, 1 and 3 (each within the scatter of the next); then compound 4.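

Among these compounds, the aromatic carbon of the five-membered ring, two ring bonds from the ring nitrogen, turns out to be a place where the choice of aryl group can move the number in this assay a long way: 3-aminophenyl in place of 2-fluorophenyl gives a 32-fold higher number from compound 2 to compound 4 (1.51 log units; beyond the scatter) and this is the first step that isolates a single change. The two groups match in size as counted, with 7 heavy atoms and one six-membered aromatic ring of carbon only in each, yet the entering group carries 1 hydrogen-bond donor and 1 hydrogen-bond acceptor where the leaving group carries neither. No measurement at hand bears on why the step is this large.

This single step changes two things on the phenyl ring together, the fluorine leaving and the amine entering, each at its own ring position, so it cannot say which of them accounts for the rise. Compounds with 2-aminophenyl, 3-fluorophenyl or 3-hydroxyphenyl at this carbon would separate the group from its position, and a carboxylic acid there would show whether the step extends beyond the amine.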